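The source may hold more compounds than are shown below. What is called first, only, known or untested is meant among the compounds shown, and "the series" means these compounds.

In an assay on isolated protein for inhibition of protein deacetylase HDAC6 (Homo sapiens) (a lower number here means a stronger inhibitor, a higher number a weaker inhibitor), compound 2 `COc1ccc(C(=O)c2ccc3c(ccn3Cc3ccc(/C=C/C(=O)NO)cc3)c2)cc1` gives 108 nM, the lower of the two numbers recorded so far; compound 1 `COc1ccc(C(=O)c2ccc3c(ccn3S(=O)(=O)c3cccc(/C=C/C(=O)NO)c3)c2)cc1OC` gives 1180 nM in this assay, a gap beyond the scatter. Compound 3 `COc1cc(C(=O)c2ccc3c(ccn3Cc3ccc(/C=C/C(=O)NO)cc3)c2)cc(OC)c1OC` has not yet been measured. It differs from compound 2 in one place: 3,4,5-trimethoxyphenyl in place of 4-methoxyphenyl on a carbonyl carbon. Going by the values given here, no step between measured compounds isolates this change, so in this assay the step from compound 2 to compound 3 is expected to be small, in either direction and not beyond the scatter. Compound 3 is therefore estimated at 130 nM, within 50 nM to 350 nM. The expected step is a 1.2-fold higher number from compound 2 to compound 3 (0.08 log units; within the scatter).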

Compound 3, half-maximal inhibitory concentration: 143 nM
Compound 3: middle estimate off by 1.1-fold (0.04 log units), on the low side, and the stated range covers the measured number.
By their numbers in this assay, from the lowest: compounds 2 and 3 (each within the scatter of the next); then compound 1.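

In this assay, going by these compounds alone, 3,4,5-trimethoxyphenyl in place of 4-methoxyphenyl on a carbonyl carbon gives a 1.3-fold higher number from compound 2 to compound 3 (0.12 log units; within the scatter), the first step that can be read at this position. Compound 2 and compound 3 cannot be told apart here, so this position accepts either group. Nothing measured here offers an explanation for this result. Going by these compounds, it remains open whether the position also accepts a group without methoxy substituents, such as an unsubstituted phenyl or a pyridine ring. On these data alone, whether an amine or a carboxylic acid on the phenyl ring would be accepted is also open.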